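Removing the methoxy from the chain: compound 4 expected

The compounds below may be only part of what the source reports. "The series", "measured", "known", "first", "only" and "open" are said of these compounds alone.

Compound 1 `C/C(=C\Cc1c(O)ccc2c1O[C@H](c1ccc(O)cc1)CC2=O)C/C=C/C(C)(C)O` in a functional assay on HT-29 cells (Homo sapiens) for cytotoxicity, read by MTT assay; a higher number here means a weaker inhibitor, a lower number a stronger inhibitor: > 10000 nM, which is a limit of the assay and not a number.
Compound 2 `C=C(CCC=C(C)C)C(O)Cc1c(O)ccc2c1O[C@H](c1ccc(O)cc1)CC2=O` in this assay: > 10000 nM, again a limit.
Compound 3 `COC(C=C(C)C)C/C(C)=C/Cc1c(O)ccc2c1O[C@H](c1ccc(O)cc1)CC2=O` in this assay: > 10000 nM, again a limit.

Compound 3 therefore stands where every measured compound stands, at the limit of > 10000 nM in this assay, at which 3 of the 3 values shown sit. Compound 4 `CC(C)=CCC/C(C)=C/Cc1c(O)ccc2c1O[C@H](c1ccc(O)cc1)CC2=O` differs from compound 3 by hydrogen in place of methoxy on a saturated chain carbon bound to a double-bonded chain carbon and a saturated chain carbon. Within the data shown here, two measured steps touch the same part of the chain: a step that the two limits leave unreadable from compound 1 to compound 2 and a step that the two limits leave unreadable from compound 1 to compound 3. Neither has a readable size or direction, as the compounds at both ends of each sit at the limit. Among the measured compounds shown here, nothing measured so far gives a number that a change of this kind could move up or down. The expectation is that compound 4 will also sit at the limit, so the expected step that the limit leaves unreadable from compound 3 to compound 4 means no change beyond the scatter. For compound 4 the estimate in this assay is 15000 nM, expected to fall between 5000 nM and 50000 nM.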

Compound 4, half-maximal inhibitory concentration: > 10000 nM
Compound 4: a limit, no number; the forecaster's own chance of this, stated with the estimate: 75%; the middle value does not contradict the limit.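

Among these compounds, compound 4 also gives only a limit of the assay and not a number, so no step among compound 1, compound 2, compound 3 and compound 4 can be read: the limit of > 10000 nM in this assay, at which 4 of the 4 values shown sit. The compounds shown leave open whether changing this chain affects the result in this assay at all.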